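This account rests on a few compounds, and the source may have more. Where it says the series, first, only, none or still open, it means among the compounds named here.

Of the compounds shown here, two have been measured in an assay on isolated protein for inhibition of N-acylethanolamine-hydrolyzing acid amidase (Homo sapiens), read by fluorescence, with a stated time of 90 min; a higher number here means a weaker inhibitor, a lower number a stronger inhibitor. Compound 1 `CC(C)c1ccc(-c2ccc(CO[C@H]3C[C@@H](N=C=S)C3)c(F)c2)cc1F` gives 227 nM there, the highest of the two numbers. Compound 2 `COc1ccc(-c2ccc(C(=O)N[C@H]3C[C@@H](N=C=S)C3)nc2)cc1`, built on a different core, gives 7.6 nM in this assay, a lower number by a margin that lies well beyond the usual scatter of repeated measurements. Among the measured compounds shown here, no single-point step between these two compounds is recorded, so the gap can only be noted, not traced to one part of the structure.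

Compound 3 `COc1ccc(-c2ccc(CO[C@H]3C[C@@H](N=C=S)C3)c(F)c2)cc1F` is an analogue of compound 1 that differs in one place: methoxy in place of isopropyl on an aromatic carbon. Everything else in the molecule stays as it is in compound 1. For the measured compounds named here, with no measured step of this kind to draw on, only a cautious expectation is possible. The step of a 1.1-fold higher number from compound 1 to compound 3 (0.04 log units; within the scatter) is expected to be small, within the scatter, in either direction. Compound 3 is therefore expected to give about 250 nM in this assay, within a range from 80 nM to 800 nM.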

Compound 3, half-maximal inhibitory concentration: 20.6 nM
Compound 3: the middle estimate sits 12-fold (1.08 log units) above what was measured; measured number outside the range, below it.
By their numbers in this assay, from the lowest: compound 2; then compound 3; then compound 1.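

In this assay, this position, on a six-membered aromatic ring of carbon only, ortho to a fluoro group and para to a large group, proves sensitive to which group it carries: methoxy in place of isopropyl gives an 11-fold lower number from compound 1 to compound 3 (1.04 log units; beyond the scatter), a change well beyond the scatter from exchanging one group alone. The exchange replaces a group of 3 heavy atoms and no hydrogen-bond acceptor with one of 2 heavy atoms and 1 hydrogen-bond acceptor, so both the size of the group and its atoms change together. Nothing measured here shows which of these differences matters, so the counts describe the change without accounting for its size.

A single pair cannot separate the loss of carbon from the arrival of oxygen, and an ethyl group, which holds no oxygen, or an ethoxy group, which keeps the oxygen on a longer chain, would pull the two apart at this position. On these data alone, whether the same exchange would give a step of similar size on a different core also remains open.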